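Aryl swap at the shared core: compound 2 to compound 3

This account rests on a few compounds, and the source may have more. Where it says the series, first, only, none or still open, it means among the compounds named here.

Going by the values given here, compound 2 `c1cn2cc(-c3ccsc3)nc(-c3ccc4ncn(C5CCCCC5)c4c3)c2n1` stands highest of the two numbers so far in a functional assay on CCRF-CEM cells (Homo sapiens) for inhibition, read by sulforhodamine B assay, with a stated time of 48 h, tested at 10 uM (on this read-out higher numbers stand for more inhibition at the one concentration tested (going by the name of the read-out) and lower numbers for less inhibition), at 29.2%. Its nearest neighbour is compound 1 `c1ccc2c(-c3cn4ccnc4c(-c4ccc5ncn(C6CCCCC6)c5c4)n3)cccc2c1`, which in this assay gives 17.5%; the step between them was a number 11.7 percentage points higher from compound 1 to compound 2 (beyond the scatter). Compound 3 `Clc1ccc(-c2cn3ccnc3c(-c3ccc4ncn(C5CCCCC5)c4c3)n2)cc1` is the unmeasured member of the series. It differs from compound 2 in one place: 4-chlorophenyl in place of thiophen-3-yl on an aromatic carbon. Among the compounds with values here, no measured step covers this particular swap; the only step in hand, from naphthalen-1-yl to thiophen-3-yl on the same aromatic carbon, was modest and beyond the scatter. With a six-membered carbon-only ring entering where a five-membered ring leaves, a small shift in this assay is expected, and for compound 3 the expected step is a number 4.2 percentage points lower from compound 2 to compound 3 (within the scatter), likely within the scatter. The estimate for compound 3 is therefore 25%, with a range from 10% to 42%.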

Compound 3, a percentage reported as inhibition, at one concentration (the size of the read-out at that concentration, not a potency): 11.4%
Compound 3: middle estimate off by 13.6 percentage points, on the high side; the measured number falls inside the stated range.
By their numbers in this assay, from the lowest: compounds 3 and 1 (each within the scatter of the next); then compound 2.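

Replacing thiophen-3-yl with 4-chlorophenyl on this aromatic carbon gives a number 17.8 percentage points lower from compound 2 to compound 3 (beyond the scatter) in this assay and so shows that the higher number of compound 2 holds against a second aryl group, not only against naphthalen-1-yl. The comparison of the two carbon-only aryl groups gives a number 6.1 percentage points lower from compound 1 to compound 3 (within the scatter) and so does not separate 4-chlorophenyl from naphthalen-1-yl at this position; among these three compounds, only the five-membered ring with a sulfur atom stands apart. No measurement at hand explains this difference.

The swap from compound 2 to compound 3 changes ring size, the sulfur atom and the chlorine together, so their shares in the step remain unresolved. Plain phenyl, furan-3-yl, thiophen-2-yl, and polar groups such as a carboxylic acid or an amine on this carbon remain open.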